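Swapping the piperidine amide for an open ester chain

A few compounds are considered here, and "the series" means these few. Any claim that something is new, unique, unknown or untested is made for them only; others in the source may bear on it.

The shared core of this small series is seen in compound 1 `COc1ccc(C[C@H]2COC(=O)[C@@H]2Cc2ccc(OCC(=O)N3CCCCC3)c(OC)c2)cc1OC`. Going by the values given here, in an ADME assay on HeLa cells (Homo sapiens) for cytotoxicity, read by MTT assay (a lower number here means a stronger inhibitor, a higher number a weaker inhibitor), compound 1 gives 293000 nM, the highest of the two numbers known so far, with compound 3 `COc1ccc(C[C@H]2COC(=O)[C@@H]2Cc2ccc(OCc3cn(-c4ccc(Br)cc4)nn3)c(OC)c2)cc1OC` nearest at 128000 nM. Compound 2 `COc1ccc(-n2cc(COc3ccc(C[C@H]4C(=O)OC[C@@H]4Cc4ccc(OC)c(OC)c4)cc3OC)nn2)cc1` reaches only the limit of this assay, >= 600000 nM, so no number is known for it. The change now considered is a group of 12 heavy atoms (7 carbon, 1 nitrogen, 4 oxygen; no ring) in place of a group of 9 heavy atoms (7 carbon, 1 nitrogen, 1 oxygen; one six-membered non-aromatic ring with 1 hetero atom), on an oxygen on an aromatic ring, which gives compound 4 `COC(=O)CNC(=O)CCC(=O)Oc1ccc(C[C@H]2C(=O)OC[C@@H]2Cc2ccc(OC)c(OC)c2)cc1OC`. Among the compounds with values here, two measured steps bear on it. Exchanging the whole group on this oxygen gave a 2.3-fold lower number from compound 1 to compound 3 (0.36 log units; beyond the scatter), and changing one substituent within that group gave an at least 4.6-fold lower number from compound 2 to compound 3 (0.67 log units; beyond the scatter), whose lower bound comes from the limit of >= 600000 nM in this assay, at which 1 of the 3 values shown sits. Both were modest, and the present exchange keeps the same attachment point while bringing a group with no ring, so no larger shift than these is expected. Compound 4 is therefore expected at 300000 nM, within 120000 nM to 700000 nM. The expected step is a 1.0-fold higher number from compound 1 to compound 4 (0.01 log units; within the scatter), that is, no change beyond the scatter.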

Compound 4, half-maximal inhibitory concentration: 179000 nM
For compound 4 the middle estimate is 1.7-fold (0.22 log units) above the measured one, and the stated range covers the measured number.
By their numbers in this assay, from the lowest: compounds 3, 4 and 1 (each within the scatter of the next, the first and the last beyond it). At a limit, above all of these: compound 2.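

At this oxygen on an aromatic ring, this assay shows a 1.6-fold lower number from compound 1 to compound 4 (0.21 log units; within the scatter), so the ((piperidin-1-yl)carbonyl)methyl group can be exchanged for a group with no ring without a change beyond the scatter. The exchange also goes from 0 hydrogen-bond donors to 1 and from 1 hydrogen-bond acceptor to 4, and even this larger difference in the counts leaves the number within the scatter of compound 1. Nothing measured here gives a reason for this result.

The compounds shown leave open what a carboxylic acid or an amine would do in this chain. They also leave open whether a much shorter or longer chain on this oxygen would move the number beyond the scatter.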